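The source may hold more compounds than are shown below. What is called first, only, known or untested is meant among the compounds shown, and "the series" means these compounds.

Measured so far:
Compound 1, `C=CCn1c(=O)n(CCCCCCCC)c2nc(N)nc(O)c21`, gives 37 uM in a functional assay (B cells) with Mus musculus as the target; a lower number here means that less compound is needed, a higher number that more compound is needed for the effect.
Compound 2, `N#Cc1ccc(Cn2c(=O)n(C3OC(CO)[C@@H](O)[C@H]3O)c3nc(N)nc(O)c32)cc1`, gives 15 uM in this assay.

Of these two numbers, compound 1 has the higher one; compound 2 sits at a number lower by more than the usual scatter. Compound 2 differs from compound 1 in more than one place, however, and the pair alone does not say which part of the molecule matters.

Compound 3, `C=CCn1c(=O)n(Cc2ccccc2)c2nc(N)nc(O)c21`, has not yet been measured. It differs from compound 1 in a single place: phenyl in place of heptyl on a saturated chain carbon bound to an aromatic nitrogen. No two measured compounds differ in exactly this way, and nothing in the numbers shown tells what this swap does on its own. A modest move toward a lower number is expected, small enough that it may well stay within the scatter, giving an expected step of a 1.5-fold lower number from compound 1 to compound 3 (0.17 log units; within the scatter). For compound 3 in this assay the estimate is 25 uM, with a plausible range from 8 uM to 80 uM.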

Compound 3, concentration for half-maximal effect: 5 uM
The estimate for compound 3 lay 5.0-fold (0.70 log units) above the measured number, and the stated range ends above it.
By their numbers in this assay, from the lowest: compound 3; then compound 2; then compound 1.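

In this assay, putting phenyl in place of heptyl on a saturated chain carbon bound to an aromatic nitrogen gives a 7.4-fold lower number from compound 1 to compound 3 (0.87 log units; beyond the scatter), a step beyond the scatter. Going by these compounds alone, this is the first change in the set made at a single place, so it shows that the group at this position alone can move the number, something the pair of compound 1 and compound 2 could not show, as those two differ in more than one place. Neither heptyl nor phenyl carries a hydrogen-bond donor, a hydrogen-bond acceptor or a net charge, the visible difference being a six-membered aromatic ring in place of an open chain, and no measurement at hand accounts for the size of the step.

As far as these compounds go, it remains open whether the aromatic ring itself matters or simply the loss of the heptyl chain, a question that cyclohexyl or a shorter chain such as butyl at this place could answer. Also open, from the compounds shown here alone, is how a phenyl carrying an amine or a carboxylic acid would behave, and whether the same swap would act alike on the core of compound 2.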